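The source may report more compounds than this note shows. Statements on the series, on what has been measured and on what is new or still open speak of the compounds shown alone.

Compound 1, `Cc1cc(Nc2cc(-c3ccccc3)[nH]n2)n2nc(SCc3cccc(Br)c3)nc2n1`, was tested in an ADME assay on GES1 cells (Homo sapiens) for inhibition, read by MTT assay, with a stated time of 72 h; on this read-out lower numbers stand for stronger inhibition and higher numbers for weaker inhibition. For compound 1 the assay returned only a limit, > 50000 nM, not a number. Two related compounds were measured alongside it. Compound 2, `Cc1cc(Nc2cc(C(C)(C)C)[nH]n2)n2nc(SCc3ccc(Br)cc3)nc2n1`, likewise gave only a limit in this assay, > 50000 nM. Among the measured compounds shown here, compound 3, `Cc1cc(Nc2ccn(Cc3ccc(F)cc3)n2)n2nc(SCc3ccc(Br)cc3)nc2n1`, is the one compound of the three for which this assay gave a number, 40500 nM. Compound 1 therefore sits at the limit of > 50000 nM in this assay, at which 2 of the 3 values shown sit, together with compound 2, while compound 3 gives a value close by; all three show weak inhibition of these cells.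

Compound 4, `Cc1cc(Nc2cc(-c3ccccc3)[nH]n2)n2nc(SCc3cccc4ccccc34)nc2n1`, has not yet been measured. It differs from compound 1 in one place: naphthalen-1-yl in place of 3-bromophenyl on a saturated chain carbon bound to a sulfur. For the measured compounds named here, no measured pair here shows such a change, so there is nothing to size the step from. Given that compound 1 already sits at the limit, compound 4 is expected to stay near it, and the step of an at least 1.1-fold lower number from compound 1 to compound 4 (0.04 log units; that floor lies within the scatter) is estimated as none beyond the scatter. Compound 4 is expected to give about 45000 nM, within a range from 20000 nM to 100000 nM.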

Compound 4, half-maximal inhibitory concentration: 36300 nM
For compound 4 the middle estimate is 1.2-fold (0.09 log units) above the measured one; the range from low to high includes it.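

Compound 1 gave only a limit, > 50000 nM. Among the compounds shown here, the single change made here therefore gives the first step at this position, and that step has a floor but no exact size: an at least 1.3-fold lower number from compound 1 to compound 4 (0.13 log units; that floor lies within the scatter). With two aromatic rings of carbon in place of one ring bearing bromine, compound 4 still shows only weak inhibition of these cells, and most of the read-outs so far are not numbers at all: the limit of > 50000 nM in this assay, at which 2 of the 4 values shown sit.

As far as these compounds go, whether the true step from the limit lies beyond the scatter stays unknown, and this single pair cannot show whether the same swap would behave alike on other compounds. Also open, from the compounds shown here alone, is how this assay would respond at this place to a group of a different kind, such as a carboxylic acid or a longer chain ending in an amine.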